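Notes on the step from compound 2 to compound 3

This account rests on a few compounds, and the source may have more. Where it says the series, first, only, none or still open, it means among the compounds named here.

- compound 1 (`O=S(=O)(/C=C/c1ccc(C(F)(F)F)cc1F)Cc1ccc(Nc2ncnc3ccc(Br)cc23)cc1`) gives 55000 nM
- compound 2 (`O=S(=O)(/C=C/c1ccc(Cl)cc1Cl)Cc1ccc(Nc2ncnc3cc(Cl)ccc23)cc1`) gives > 100000 nM as a limit of the assay

In a functional assay on SW-620 cells (Homo sapiens) (on this read-out lower numbers stand for stronger inhibition of growth and higher numbers for weaker inhibition of growth), compound 2 gives > 100000 nM, which is a limit and not a number. Its place is that of the limit of > 100000 nM in this assay, at which 1 of the 2 values shown sits, and nothing finer can be read from it. Going by the values given here, compound 1 gives 55000 nM, the only number so far.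

Compound 3 (`O=S(=O)(/C=C/c1ccc(C(F)(F)F)cc1F)Cc1ccc(Nc2ncnc3cc(Cl)ccc23)cc1`) keeps all of compound 2 except one group: 2-fluoro-4-(trifluoromethyl)phenyl in place of 2,4-dichlorophenyl on a double-bonded chain carbon bound to a double-bonded chain carbon. In words, 2-fluoro-4-(trifluoromethyl)phenyl takes the place of 2,4-dichlorophenyl on a double-bonded chain carbon bound to a double-bonded chain carbon.

Among the compounds with values here, no step between measured compounds that differ in one place exists to size this change. The entering group is also carried by compound 1, which gives 55000 nM, so a modest move toward stronger inhibition of growth is expected. The estimated step of an at least 1.6-fold lower number from compound 2 to compound 3 (0.22 log units; that floor lies within the scatter) is expected in this assay and is counted from a limit, so it stays rough. A further reading at the limit would not be surprising.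

For compound 3 the estimated value is 60000 nM, with an expected range from 25000 nM to 130000 nM in this read-out.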

Compound 3, concentration for 50% growth inhibition: > 100000 nM
Compound 3 was reported as a limit; the forecaster's own chance of this, stated with the estimate: 35%; middle value at least 1.6-fold (0.22 log units) from the limit.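

In this assay compound 3 gives > 100000 nM, which is a limit of the assay. Compound 2 also stands at a limit, so the step from one to the other cannot be read, and 2-fluoro-4-(trifluoromethyl)phenyl in place of 2,4-dichlorophenyl on a double-bonded chain carbon bound to a double-bonded chain carbon has no measurable size here; the shared entering group alone did not bring compound 3 to a number. Going by these compounds alone, the only readable comparison is an at least 1.8-fold higher number from compound 1 to compound 3 (0.25 log units; that floor lies within the scatter), for the chlorine-bearing group in place of the bromine-bearing group on a nitrogen on an aromatic ring, and since its floor lies within the scatter, it does not establish a real loss on that exchange.

As far as these compounds go, it remains open whether the exchange of bromine for chlorine on the shared core has any effect beyond the scatter. Also open is whether an amine or a carboxylic acid in place of the aryl group on the double-bonded chain carbon would give a number rather than a further reading at the top of the range: the limit of > 100000 nM in this assay, at which 2 of the 3 values shown sit.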